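A bromo group on a compound at the limit

The source may hold more compounds than are shown below. What is called first, only, known or untested is meant among the compounds shown, and "the series" means these compounds.

Compound 1 `COc1ccc(-c2cnnn2-c2cc(OC)c(OC)c(OC)c2)cc1N`: 11 nM
Compound 2 `COc1ccc(-c2cn(Cc3cc(OC)c(OC)c(OC)c3)nn2)cc1`: > 10000 nM

In a functional assay on K562 cells (Homo sapiens) for cytotoxicity, read by MTT assay, with a stated time of 5 days (a lower number here means a stronger inhibitor, a higher number a weaker inhibitor), compound 1 gives 11 nM. Compound 2 gives > 10000 nM, which is a limit of the assay and not a number. Compound 2 therefore has no exact position on the scale, only (the limit of > 10000 nM in this assay, at which 1 of the 2 values shown sits).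

Compound 3 `COc1ccc(-c2cn(Cc3cc(OC)c(OC)c(OC)c3)nn2)cc1Br` differs from compound 2 in one place: bromo in place of hydrogen on an aromatic carbon. A bromo takes the place of hydrogen on an aromatic carbon, ortho to a methoxy group, so that 4-methoxyphenyl becomes 3-bromo-4-methoxyphenyl.

Going by the values given here, no pair of measured compounds shows what this change does, so its size cannot be read from the data. The starting point is also uncertain, since compound 2 is known only through the limit > 10000 nM. Only a small gain toward stronger inhibition is expected in this assay, and a second limit is quite possible. The expected move is an at least 1.2-fold lower number from compound 2 to compound 3 (0.09 log units; that floor lies within the scatter). For compound 3 the estimated value is 8000 nM, with an expected range of 1500 nM to 20000 nM.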

Compound 3, half-maximal inhibitory concentration: > 10000 nM
Compound 3: no number, only a limit (the forecaster's own chance of this, stated with the estimate: 55%); at least 1.2-fold (0.09 log units) between middle value and limit.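

In this assay compound 3 gives > 10000 nM, which is a limit of the assay and not a number. Compound 2 sits at a limit as well, so no step from one to the other can be read: the limit of > 10000 nM in this assay, at which 2 of the 3 values shown sit.

The compounds shown leave open whether bromo in place of hydrogen changes the value at all, and how far compound 2 and compound 3 each lie past that limit.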